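The source may report more compounds than this note shows. Statements on the series, on what has been measured and on what is new or still open speak of the compounds shown alone.

Compound 1 `Nc1n[nH]c2cc(-c3cn([C@@H]4CN[C@H](C(=O)Nc5ccc(Cl)cc5Cl)C4)nn3)ccc12`: 28400 nM
Compound 2 `CC(C)(C)OC(=O)N1C[C@@H](n2cc(-c3ccc4nc(N)sc4n3)nn2)C[C@H]1C(=O)Nc1ccc(Cl)cc1Cl`: 8940 nM
Compound 3 `Nc1nc2ccc(-c3cn([C@@H]4CN[C@H](C(=O)Nc5ccc(Cl)c(C(F)(F)F)c5)C4)nn3)nc2s1`: 26200 nM

In a functional assay on K562 cells (Homo sapiens) for inhibition, read by MTT assay, with a stated time of 48 h (a lower number here means a stronger inhibitor, a higher number a weaker inhibitor), compound 3 holds the second highest of the three numbers. It lies within the scatter of compound 1, while compound 2 has a lower number, beyond the scatter.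

Compound 4 `Nc1nc2ccc(-c3cn([C@@H]4CN[C@H](C(=O)Nc5ccc(Cl)cc5Cl)C4)nn3)nc2s1` has not yet been measured. It differs from compound 3 in one place, with 2,4-dichlorophenyl in place of 4-chloro-3-(trifluoromethyl)phenyl on an amide-type nitrogen.

Among the compounds with values here, no measured pair isolates this change. Compound 1 carries the same 2,4-dichlorophenyl and gives 28400 nM, and compound 2 also carries it and gives 8940 nM, but both differ from compound 4 elsewhere. The value of compound 1 suggests that the group need not lower the number, whereas compound 2 leaves room for a modest drop.

Only a small downward move, within the scatter, is therefore expected, and the estimated step is a 1.2-fold lower number from compound 3 to compound 4 (0.08 log units; within the scatter). For compound 4 the estimated value is 22000 nM, with an expected range of 10000 nM to 48000 nM.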

Compound 4, half-maximal inhibitory concentration: 24500 nM
Compound 4: middle estimate off by 1.1-fold (0.05 log units), on the low side; low and high end bracket the measured number.
By their numbers in this assay, from the lowest: compound 2; then compounds 4, 3 and 1 (each within the scatter of the next).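

In this assay, 2,4-dichlorophenyl in place of 4-chloro-3-(trifluoromethyl)phenyl on the amide-type nitrogen gives a 1.1-fold lower number from compound 3 to compound 4 (0.03 log units; within the scatter), so these two groups cannot be told apart at this position. Exchanging one aromatic group for the other on the aromatic carbon gives a 1.2-fold lower number from compound 1 to compound 4 (0.06 log units; within the scatter), which also leaves no readable difference. Among these steps, only hydrogen in place of tert-butoxycarbonyl on the amine nitrogen in a ring goes beyond the scatter, with a 2.7-fold higher number from compound 2 to compound 4 (0.44 log units; beyond the scatter).

From the compounds shown here alone, whether an unsubstituted phenyl or a pyridine ring on the amide-type nitrogen would shift the number remains open, as does whether an acetyl group on the ring nitrogen would match the effect of tert-butoxycarbonyl. Nothing available accounts for any of these steps.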